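A few compounds are considered here, and "the series" means these few. Any claim that something is new, unique, unknown or untested is made for them only; others in the source may bear on it.

Working notes on the series. The shared core of compound 1 `c1nc(NC2CC2)c2ncn(CC3CC3)c2n1` carries a cyclopropylamino group and a substituent on a saturated chain carbon bound to an aromatic nitrogen; in a functional assay on the whole organism for antagonist activity, with Rattus norvegicus as the target (on this read-out higher numbers stand for an effect only at larger amounts of compound and lower numbers for an effect already at smaller amounts), compound 1 gives 4 mg/kg. Compound 2 `CC(C1CC1)n1cnc2c(NC3CC3)ncnc21` has been run repeatedly, and in this assay compound 2 gives 2 mg/kg; 4.5 mg/kg; 12.5 mg/kg (3 entries), a spread recorded as the several entries of compound 2 in this assay, 2 mg/kg; 4.5 mg/kg; 12.5 mg/kg (3 entries) that shows how far repeat determinations of one substance can lie apart here. For the measured compounds named here, compound 3 `CCCn1cnc2c(NC3CC3)ncnc21` carries a propyl group at that position, and in this assay compound 3 gives 6 mg/kg, which lies within the scatter of compound 1, so no order between the two can be read from the numbers; the change a 1.5-fold higher number from compound 1 to compound 3 (0.18 log units; within the scatter) is the only measured step at this position.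

Compound 4 `CSCn1cnc2c(NC3CC3)ncnc21` is the next member: methylsulfanyl in place of ethyl on a saturated chain carbon bound to an aromatic nitrogen. Going by the values given here, the only measured step that bears on this position, from compound 1 to compound 3, stayed within the scatter, and no measured pair shows the effect of a sulfur-containing chain at this position. The expected step is therefore no change at the digits printed from compound 3 to compound 4 (within the scatter), none beyond the scatter. For compound 4 a value of 6 mg/kg is expected in this assay, with a range from 2.5 mg/kg to 15 mg/kg.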

Compound 4, dose for half-maximal effect: 23 mg/kg
Compound 4: middle estimate off by 3.8-fold (0.58 log units), on the low side, and the stated range ends below it.
By their numbers in this assay, from the lowest: compounds 1 and 3 (each within the scatter of the next); then compound 4.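

For the compounds shown here, at the position on a saturated chain carbon bound to an aromatic nitrogen, the substituent now makes a readable difference in this assay: methylsulfanyl in place of ethyl gives a 3.8-fold higher number from compound 3 to compound 4 (0.58 log units; beyond the scatter), the first step at this position that lies beyond the scatter. Methylsulfanyl in place of cyclopropyl points the same way, with a 5.8-fold higher number from compound 1 to compound 4 (0.76 log units; beyond the scatter), so both comparisons with compound 4 show an effect only at larger amounts of compound. Both steps are modest and rest on one entry for compound 4, and repeat entries of a single substance can lie far apart on this read-out: the several entries of compound 2 in this assay, 2 mg/kg; 4.5 mg/kg; 12.5 mg/kg (3 entries).

The compounds shown do not separate the sulfur atom from the chain that carries it, and methoxymethyl or a longer chain such as butyl at this place would bear on that question. Going by these compounds alone, with several entries and no single number, compound 2 cannot be placed in the order of the other compounds, and no step involving it can be read.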